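This account rests on a few compounds, and the source may have more. Where it says the series, first, only, none or still open, it means among the compounds named here.

Measured so far in a functional assay on SK-N-SH cells (Homo sapiens) for inhibition, read by MTT assay, with a stated time of 72 h, tested at 30 uM; on this read-out lower numbers stand for less inhibition of growth and higher numbers for more inhibition of growth at the one concentration tested:
- compound 1, `C=CCc1ccc(OCc2cn(-c3ccccc3CO)nn2)c(O)c1`: 12.9%
- compound 2, `C=CCc1cc(O)c(O)c(CN2CCC(CO)CC2)c1`: 21.9%
- compound 3, `C=CCc1ccc(OCc2cn(-c3cc(OC)c(OC)c(OC)c3)nn2)c(O)c1`: 44.1%

Compound 1 holds the lowest of the three numbers. The gap to compound 2 lies within the usual scatter, so the two cannot be ordered. Compound 3 stands well apart, its value being beyond the scatter above that of compound 1; no single-point step between any two of these compounds is available, so only the bare values can be compared.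

The next compound in the series is compound 4, `C=CCc1ccc(OCc2cn(-c3ccc(Br)cc3)nn2)c(O)c1`, not yet measured in this assay. It differs from compound 1 in one place: 4-bromophenyl in place of 2-(hydroxymethyl)phenyl on an aromatic nitrogen

Among the measured compounds shown here, no measured step describes this kind of change here, so the expectation rests on the spread of the three values alone. A modest rise in growth inhibition from compound 1 to compound 4 is expected, of a size close to the edge of the scatter rather than clearly beyond it: the estimated step is a number 12.1 percentage points higher from compound 1 to compound 4 (beyond the scatter). On that basis compound 4 is estimated at 25%, with a range from 5% to 50%.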

Compound 4, percent growth inhibition at one concentration: 38.3%
The estimate for compound 4 lay 13.3 percentage points below the measured number, and the stated range covers the measured number.
By their numbers in this assay, from the lowest: compounds 1 and 2 (each within the scatter of the next); then compounds 4 and 3 (each within the scatter of the next).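

In this assay, the aryl group on the aromatic nitrogen of the five-membered ring is now shown to matter: 4-bromophenyl in place of 2-(hydroxymethyl)phenyl gives a number 25.4 percentage points higher from compound 1 to compound 4 (beyond the scatter), the first single-place step in the series. With that group, compound 4 at 38.3% lies within the scatter of compound 3 at 44.1%, so two different aryl groups at this place give values that cannot be ordered, and both stand apart from the 2-(hydroxymethyl)phenyl of compound 1. No measurement is available that explains the step.

The step removes a hydroxymethyl group and brings in a bromine at the same time, so the compounds shown do not separate the loss of one from the gain of the other. A plain phenyl group at this place would help to divide the step between the two, and a 4-aminophenyl or 4-carboxyphenyl group would show whether the level of compound 4 is tied to bromine at all.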